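A Benzimidazole-to-Indole Swap on a Diphenylmethylpiperazine Chain

This account rests on a few compounds, and the source may have more. Where it says the series, first, only, none or still open, it means among the compounds named here.

Of the compounds shown here, three have been measured in an assay on RPMI-8226 cells for antagonist activity at P2X purinoceptor 7 (Homo sapiens), read by calcium flux; on this read-out lower numbers stand for stronger inhibition and higher numbers for weaker inhibition. Compound 1 `O=c1[nH]c2ccccc2n1CCCN1CCN(S(=O)(=O)c2ccc([N+](=O)[O-])cc2)CC1` reaches only the limit of the assay, > 10000 nM, which is a limit rather than a number (the limit of > 10000 nM in this assay, at which 1 of the 3 values shown sits). Compound 2 `O=c1[nH]c2ccccc2n1CCCN1CCC(C(O)(c2ccccc2)c2ccccc2)CC1` gives 7500 nM. Compound 3 `Cc1cc2ncn(CCCCN3CCN(C(c4ccccc4)c4ccccc4)CC3)c2cc1C` gives 770 nM, the lower of the two numbers, and its gap to compound 2 lies beyond the scatter.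

Compound 4 `Fc1cc2ccn(CCCCN3CCN(C(c4ccccc4)c4ccccc4)CC3)c2cc1F` has not yet been measured in this assay. It differs from compound 3 in one place: a group of 11 heavy atoms (8 carbon, 1 nitrogen, 2 fluorine; one five-membered aromatic ring with 1 hetero atom, one six-membered aromatic ring of carbon only) in place of a group of 11 heavy atoms (9 carbon, 2 nitrogen; one five-membered aromatic ring with 2 hetero atoms, one six-membered aromatic ring of carbon only), on a saturated chain carbon, four bonds along the chain from an amine nitrogen in a ring. Among the measured compounds shown here, no measured pair shows this kind of change, so there is no direct guide for its size. The four-carbon chain, the piperazine and the diphenylmethyl group are kept. The step of a 1.0-fold higher number from compound 3 to compound 4 (0.02 log units; within the scatter) is expected to be small, within the scatter, with no firm direction. Compound 4 is accordingly estimated at 800 nM, with a range from 250 nM to 2500 nM.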

Compound 4, half-maximal inhibitory concentration: 130 nM
Estimate against measurement, compound 4: 6.2-fold (0.79 log units) above; the whole stated range lies above it.
By their numbers in this assay, from the lowest: compound 4; then compound 3; then compound 2. At a limit, above all of these: compound 1.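

In this assay, putting the group of 8 carbon, 1 nitrogen and 2 fluorine in place of 5,6-dimethyl-1H-benzimidazol-1-yl gives a 5.9-fold lower number from compound 3 to compound 4 (0.77 log units; beyond the scatter), so the group held on this saturated chain carbon affects the read-out even when its heavy-atom count stays the same. The earlier compounds shown here could not show this, since no two of them formed a pair differing in one place. Nothing measured here gives a reason for the step.

The change swaps the ring nitrogen count and the substituents together, so the compounds shown do not separate the two; a benzimidazol-1-yl group carrying fluorine, or the entering group with methyl in place of fluorine, would bear on that. From the compounds shown here alone, whether the step holds with a shorter or longer chain also remains open.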